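The source may report more compounds than this note shows. Statements on the series, on what has been measured and on what is new or still open speak of the compounds shown alone.

Measured so far in a functional assay on HCT-116 cells (Homo sapiens) for antiproliferative activity, read by MTT assay, with a stated time of 48 h (on this read-out higher numbers stand for weaker inhibition and lower numbers for stronger inhibition), are two compounds:
- compound 1 (`CCCCCCC(CCO)n1cnc2c(Cl)nc(Cl)nc21`) gives 12100 nM as a number
- compound 2 (`CCCCCCC(CCO)n1cnc2c(N)nc(Cl)nc21`) gives > 50000 nM as a limit of the assay and not a number

Compound 2 stands at the limit of > 50000 nM in this assay, at which 1 of the 2 values shown sits, and so has no exact place on the scale. Compound 3 (`CCCCCCCCC(CCO)n1cnc2c(N)nc(Cl)nc21`) differs from compound 2 in its chain, by ethyl in place of hydrogen on a saturated chain carbon, seven bonds along the chain from an aromatic nitrogen and in nothing else. Among the measured compounds shown here, the one measured step is an at least 4.1-fold higher number from compound 1 to compound 2 (0.61 log units; beyond the scatter) and it lies on an aromatic carbon, not on the chain. It shows that a single change can move the number in this assay beyond the scatter, but it gives no size for a change on the chain. The expectation is therefore weak: a modest fall in the number, or a second result at the limit. The expected change is an at least 1.6-fold lower number from compound 2 to compound 3 (0.22 log units; that floor lies within the scatter) and its size is loose. Compound 2 gives only a limit to count from. The estimate for compound 3 is 30000 nM with 9000 nM to 80000 nM as its expected range.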

Compound 3, half-maximal inhibitory concentration: 21000 nM
Estimate against measurement, compound 3: 1.4-fold (0.15 log units) above; measured number inside the range.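

In this assay, among the compounds shown here, ethyl in place of hydrogen on a saturated chain carbon, seven bonds along the chain from an aromatic nitrogen, gives an at least 2.3-fold lower number from compound 2 to compound 3 (0.37 log units; beyond the scatter) as the only measured step on the chain. For the compounds shown here, the one earlier step lay on an aromatic carbon, so this position now shows that a change on the chain can also move the number beyond the usual scatter. Its true size remains unknown because compound 2 has a limit of the assay and not a number as its starting point: the limit of > 50000 nM in this assay, at which 1 of the 3 values shown sits.

Going by these compounds alone, whether a longer chain than the one in compound 3 would lower the number further remains open. So does the outcome of placing an amine or a carboxylic acid on this chain.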